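Putting a longer chain back on compound 2

A few compounds are considered here, and "the series" means these few. Any claim that something is new, unique, unknown or untested is made for them only; others in the source may bear on it.

Within the data shown here, in a functional assay on SK-MEL-5 cells (Homo sapiens) for antiproliferative activity (on this read-out lower numbers stand for stronger inhibition of growth and higher numbers for weaker inhibition of growth), compound 2 `CC(C)(C)C(=O)OCC1(CO)C/C(=C\CCCCCCCCCCCO)C(=O)O1` gives 5.81 ug/mL, the higher of the two numbers measured so far. Among the measured compounds shown here, the only comparison is compound 1 `COCCCCCCCCCCCCCCC/C=C1\CC(CO)(COC(=O)C(C)(C)C)OC1=O`, which gives 1.75 ug/mL. Compound 3 `CC(C)(C)C(=O)OCC1(CO)C/C(=C\CCCCCCCCCCCCCCC=O)C(=O)O1` has not been measured and differs from compound 2 by one change: 3-formylpropyl in place of hydroxy on a saturated chain carbon, ten or more bonds along the chain from a double-bonded chain carbon. This is 3-formylpropyl in place of hydroxy on a saturated chain carbon, ten or more bonds along the chain from a double-bonded chain carbon.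

For the measured compounds named here, one measured step bears on this change. At the same place, hydroxy in place of 4-methoxybutyl gave a 3.3-fold higher number from compound 1 to compound 2 (0.52 log units; beyond the scatter), a modest step beyond the usual scatter. Compound 3 again replaces the hydroxy of compound 2 with a longer group, so that step may be largely reversed. However, no measured compound carries a formyl group, and a single step is thin evidence. A modest move towards stronger inhibition of growth in this assay is therefore expected, with an estimated 2.3-fold lower number from compound 2 to compound 3 (0.37 log units; beyond the scatter). The estimate for compound 3 is 2.5 ug/mL, with an expected range of 1 ug/mL to 6.5 ug/mL.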

Compound 3, concentration for 50% growth inhibition: > 10 ug/mL
Compound 3: no number, only a limit; the forecaster's own chance of this, stated with the estimate: 5%; at least 4.0-fold (0.60 log units) between middle value and limit.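

Compound 3 reaches no number in this assay, only a limit: the limit of > 10 ug/mL in this assay, at which 1 of the 3 values shown sits.

This shows that the far end of the long chain matters at this position, not just the presence of a long chain: formyl in place of methoxymethyl gives an at least 5.7-fold higher number from compound 1 to compound 3 (0.75 log units; beyond the scatter), so a long chain alone does not bring back the lower number of compound 1. Against the shorter hydroxy chain the reading is less firm, since 3-formylpropyl in place of hydroxy gives an at least 1.7-fold higher number from compound 2 to compound 3 (0.23 log units; that floor lies within the scatter), and that floor alone does not separate the two compounds, although the lower number expected for compound 3 clearly did not appear.

As far as these compounds go, the true value of compound 3 remains unknown, so how far it really stands from compound 2 is still open. Also open, from the compounds shown here alone, is which chain ends this position tolerates, for example whether a carboxylic acid, an amine or a simple methyl at the end of the same long chain would stay close to compound 1 or behave like compound 3.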